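Extending the Ester Chain by a Further Methyl

This account rests on a few compounds, and the source may have more. Where it says the series, first, only, none or still open, it means among the compounds named here.

Compound 2 `CCOC(=O)CNC(=O)C(CSc1ccc([N+](=O)[O-])cc1[N+](=O)[O-])NC(=O)CCC(NC(=O)OCc1ccccc1)C(=O)O` stands highest of the two compounds measured in a physicochemical assay for lipophilicity (on this read-out higher numbers stand for higher lipophilicity and lower numbers for lower lipophilicity), where compound 2 gives 1.82. Its nearest neighbour is compound 1 `COC(=O)CNC(=O)C(CSc1ccc([N+](=O)[O-])cc1[N+](=O)[O-])NC(=O)CCC(NC(=O)OCc1ccccc1)C(=O)O`, which in this assay gives 1.32. Among the compounds with values here, the single measured step, a number 0.50 log units higher from compound 1 to compound 2 (beyond the scatter), arises from methyl in place of hydrogen on a saturated chain carbon bound to an oxygen next to a carbonyl group.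

Compound 3 `CCCOC(=O)CNC(=O)C(CSc1ccc([N+](=O)[O-])cc1[N+](=O)[O-])NC(=O)CCC(NC(=O)OCc1ccccc1)C(=O)O` differs from compound 2 by methyl in place of hydrogen on a saturated chain carbon, two bonds along the chain from an oxygen next to a carbonyl group, a change that, cut one bond further out, reads as ethyl to propyl. Within the data shown here, the only step that bears on it is the one from compound 1 to compound 2, the same kind of change at the same place, which moved the number by a modest amount beyond the scatter. A rise of similar size is therefore expected for compound 3 in this assay, namely a number 0.50 log units higher from compound 2 to compound 3 (beyond the scatter). Compound 3 is thus estimated at 2.32, within a range from 2 to 2.65.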

Compound 3, partition coefficient: 2.31
Compound 3: the middle estimate sits 0.01 log units above what was measured; low and high end bracket the measured number.
By their numbers in this assay, from the lowest: compound 1; then compound 2; then compound 3.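

In this assay the change from ethyl to propyl, on a saturated chain carbon two bonds along the chain from an oxygen next to a carbonyl group, gives a number 0.49 log units higher from compound 2 to compound 3 (beyond the scatter) and so adds a second modest rise to the earlier a number 0.50 log units higher from compound 1 to compound 2 (beyond the scatter) on the same chain. Read across the whole series, the change of ethyl in place of hydrogen gives a number 0.99 log units higher from compound 1 to compound 3 (beyond the scatter) and the order follows the chain from methyl through ethyl to propyl, with no compound shown going against it. Nothing available explains the size of these steps. Going by these compounds, whether a butyl chain would extend this run remains open, as does what a branched isopropyl group or a chain ending in an amine would do. These three compounds speak only for short straight chains on this one shared core.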